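A few compounds are considered here, and "the series" means these few. Any claim that something is new, unique, unknown or untested is made for them only; others in the source may bear on it.

For the measured compounds named here, compound 1 `Cc1ccc(C2=NN(c3ccc(S(C)(=O)=O)cc3)C(=O)CC2)cc1` is one of two compounds measured in a functional assay on the whole organism (strain Wistar) for inhibition, with Rattus norvegicus as the target, read by paw edema, with stated times of 30 min and 3 h, at a dose of 0.05 mmol/kg by the oral route; on this read-out lower numbers stand for less inhibition and higher numbers for more inhibition at the one dose given (going by the name of the read-out). In this assay compound 1 gives 46.7%, the lowest of the two numbers. Its nearest neighbour is compound 2 `CS(=O)(=O)c1ccc(N2N=C(c3ccc(Oc4ccccc4)cc3)CCC2=O)cc1`, which in this assay gives 50%; the step of a number 3.3 percentage points higher from compound 1 to compound 2 (within the scatter) comes from a phenoxy in place of methyl on an aromatic carbon and lies within the scatter.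

Compound 3 `CS(=O)(=O)c1ccc(N2N=C(c3ccc(O)c(Cl)c3)CCC2=O)cc1` has not yet been measured. It differs from compound 1 by 3-chloro-4-hydroxyphenyl in place of 4-methylphenyl on a carbon with a double bond to nitrogen. No measured step bears directly on this exchange: the only step shown, from compound 1 to compound 2, swapped one group for another at the same carbon and gave a change within the scatter, and the 3-chloro-4-hydroxyphenyl group is untested here. On this thin basis a step of a number 0.3 percentage points higher from compound 1 to compound 3 (within the scatter) is expected, that is, nothing beyond the scatter. Compound 3 is therefore estimated at 47% in this assay, with a range from 30% to 63%.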

Compound 3, a percentage reported as inhibition, in the whole organism at one dose (the size of the read-out at that dose, not a potency): 43.3%
For compound 3 the middle estimate is 3.7 percentage points above the measured one, and the stated range covers the measured number.
By their numbers in this assay, from the lowest: compounds 3, 1 and 2 (each within the scatter of the next).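

In this assay the exchange of 4-methylphenyl for 3-chloro-4-hydroxyphenyl on the carbon with a double bond to nitrogen gives a number 3.4 percentage points lower from compound 1 to compound 3 (within the scatter) and so does not separate compound 3 from compound 1. This entering group carries a hydrogen-bond donor and a hydrogen-bond acceptor, which 4-methylphenyl lacks, yet the read-out at the one dose given shows no difference beyond the scatter. No available evidence connects this result to any property of the group.

The compounds shown leave open what the chlorine and the hydroxyl each contribute on their own, since they enter together. They also leave open whether an aromatic ring bearing an amine or a carboxylic acid at this position would move the number beyond the scatter.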